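The source may report more compounds than this note shows. Statements on the series, on what has been measured and on what is new or still open speak of the compounds shown alone.

Compound 1 `Cc1c(Cl)cccc1Oc1cccn2c([C@]34CCC(C[C@H]3O)C4(C)C)nnc12`: 21%
Compound 2 `Cc1c(Cl)cccc1Oc1cccn2c(C3CCC(C)(O)CC3)nnc12`: 97%

In an ADME assay on microsomes from liver (Mus musculus) for metabolic stability, with a stated time of 10 min (a lower number here means that less of the compound is left, a higher number that more of the compound is left), compound 2 holds the higher of the two numbers, and its gap to compound 1 lies beyond the usual scatter. Compound 3 `Cc1c(Cl)cccc1Oc1cccn2c(C3CCCCCC3O)nnc12` has not yet been measured. It has the same atoms as compound 2, joined differently: 2-hydroxycycloheptyl in place of 4-hydroxy-4-methylcyclohexyl on an aromatic carbon. In words, 2-hydroxycycloheptyl stands in place of 4-hydroxy-4-methylcyclohexyl on an aromatic carbon.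

For the measured compounds named here, no measured pair isolates this change, so any expectation is rough. Compound 2 at 97% leaves almost no room upward. Compound 1 at 21% shows that a compound with the shared core and another hydroxyl-bearing group can lie much lower. A fall beyond the scatter is therefore expected, and the estimated change is a number 52 percentage points lower from compound 2 to compound 3 (beyond the scatter). Compound 3 is estimated at 45%, within an expected range of 15% to 80%.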

Compound 3, percent of the compound remaining: 43%
Compound 3: the middle estimate sits 2 percentage points above what was measured; low and high end bracket the measured number.
By their numbers in this assay, from the lowest: compound 1; then compound 3; then compound 2.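

In this assay, for the compounds shown here, swapping 4-hydroxy-4-methylcyclohexyl for 2-hydroxycycloheptyl gives a number 54 percentage points lower from compound 2 to compound 3 (beyond the scatter), the first direct reading of a change at this position. The aromatic carbon between two ring nitrogen atoms therefore carries groups that behave very differently in this assay, even though the two groups have the same heavy-atom, hydrogen-bond donor and acceptor counts. Nothing measured here explains why the number falls.

Ring size, the place of the hydroxyl and the loss of the methyl all change in this single step, so the compounds shown cannot say which of them matters. A 2-hydroxycyclohexyl group would bear on ring size, and an aminocycloheptyl group would show whether the hydroxyl itself can be replaced.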